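The source may report more compounds than this note shows. Statements on the series, on what has been measured and on what is new or still open speak of the compounds shown alone.

Compound 1 `COc1cccc(OC)c1C(=O)Nc1c[nH]nc1C(=O)NC1CCC1` was tested in an ADME assay on MRC5 cells (Homo sapiens) for inhibition, with a stated time of 72 h; on this read-out higher numbers stand for an effect only at larger amounts of compound and lower numbers for an effect already at smaller amounts. In this assay compound 1 reaches only the limit of the assay, reported as > 50000 nM, not a measured number. The same holds for compound 2 `COc1cccc(OC)c1C(=O)Nc1c[nH]nc1C(=O)NC1CCN(C(=O)OC(C)(C)C)CC1`, which in this assay also gives the limit > 50000 nM. Both values sit at the same boundary (the limit of > 50000 nM in this assay, at which 2 of the 2 values shown sit), so no step between measured compounds can be calculated and compound 1 cannot be placed above or below any other compound on the numbers shown.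

Compound 3 `COc1cccc(OC)c1C(=O)Nc1c[nH]nc1C(=O)Nc1ccncc1` is the next structure to be measured. It differs from compound 1 in one place pyridin-4-yl in place of cyclobutyl on an amide-type nitrogen: cyclobutylcarbamoyl becomes (pyridin-4-yl)carbamoyl on the shared core. Among the measured compounds shown here, with no measured step to lean on, the expectation is a step from compound 1 to compound 3 of about a number no higher from compound 1 to compound 3 (the limit leaves the size open), which is no more than the scatter, because both measured compounds sit at the limit (the limit of > 50000 nM in this assay, at which 2 of the 2 values shown sit). Compound 3 is therefore expected to give roughly 50000 nM in this assay, estimated somewhere between 15000 nM and 100000 nM, most likely again as a limit.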

Compound 3, half-maximal effective concentration: > 50000 nM
Compound 3: only a limit was reported (the forecaster's own chance of this, stated with the estimate: 70%); the middle value sits exactly at the limit.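

In this assay compound 3 gives > 50000 nM, a limit and not a number. Compound 1 also sits at a limit, so no step between compound 1 and compound 3 can be read: the limit of > 50000 nM in this assay, at which 3 of the 3 values shown sit.

The compounds shown leave open what change on the amide-type nitrogen, if any, would bring a measurable value in this assay.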